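A few compounds are considered here, and "the series" means these few. Any claim that something is new, unique, unknown or untested is made for them only; others in the source may bear on it.

Of the compounds shown here, two from this set have been measured in a functional assay on MCF7 cells (Homo sapiens) for inhibition, read by MTT assay, with a stated time of 72 h; on this read-out higher numbers stand for weaker inhibition and lower numbers for stronger inhibition. Compound 1, `Cc1cc(Nc2ccn(Cc3ccccc3)n2)n2nc(SCc3ccc(Br)cc3)nc2n1`, gives 15800 nM in this assay. Compound 2, `Cc1cc(Nc2cc(-c3ccccc3)[nH]n2)n2nc(SCc3cccc(Br)c3)nc2n1`, gives 5140 nM in this assay, the lower of the two numbers shown, and the gap between compound 2 and compound 1 is larger than the usual scatter of repeated measurements.

Compound 3, `Cc1cc(Nc2cc(-c3ccccc3)[nH]n2)n2nc(SCC3CC3)nc2n1`, is the next compound to be measured. It differs from compound 2 in a single place: cyclopropyl in place of 3-bromophenyl on a saturated chain carbon bound to a sulfur. Among the measured compounds shown here, no step between two measured compounds shows what this kind of change does here, so its effect can only be estimated. A smaller group enters where a larger one leaves, and the step expected from compound 2 to compound 3 in this assay is a 2.3-fold higher number from compound 2 to compound 3 (0.37 log units; beyond the scatter), toward weaker inhibition. On that basis compound 3 is expected to give about 12000 nM in this assay, with a likely range from 4000 nM to 40000 nM.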

Compound 3, half-maximal inhibitory concentration: > 50000 nM
Compound 3: no number, only a limit; the forecaster's own chance of this, stated with the estimate: 15%; at least 4.1-fold (0.61 log units) between middle value and limit.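

On a saturated chain carbon bound to a sulfur, cyclopropyl in place of 3-bromophenyl gives an at least 9.7-fold higher number from compound 2 to compound 3 (0.98 log units; beyond the scatter) in this assay. Among the compounds shown here, this is the first single-place comparison in the set, and it shows that inhibition at this position depends on which group is present. The value of compound 3 is a limit of the assay and not a number, so the step has no known upper end: the limit of > 50000 nM in this assay, at which 1 of the 3 values shown sits.

The two groups differ at once in the bromine, in aromatic against non-aromatic ring, and in ring size, and this one step cannot separate those differences. Going by these compounds, a plain phenyl without the bromine, or a cyclohexyl on the same carbon, would pull them apart, and whether any small group can be kept here also remains open.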